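Replacing pyrrolidin-2-yl with 4-hydroxyphenyl on compound 2

A few compounds are considered here, and "the series" means these few. Any claim that something is new, unique, unknown or untested is made for them only; others in the source may bear on it.

In a functional assay on LNCaP cells (Homo sapiens) for antiproliferative activity, read by MTT assay, with a stated time of 24 h (on this read-out higher numbers stand for weaker inhibition and lower numbers for stronger inhibition), compound 1 `c1ccc(-c2noc(-c3ccncc3)n2)cc1` gives 710000 nM, while compound 2 `COc1ccc(-c2noc(C3CCCN3)n2)cc1OC1CCCC1` gives 43 nM, the lower of the two numbers by a gap far beyond the usual scatter. Compound 3 `COc1ccc(-c2noc(-c3ccc(O)cc3)n2)cc1OC1CCCC1` has 4-hydroxyphenyl in place of pyrrolidin-2-yl on an aromatic carbon. Among the compounds with values here, no measured pair isolates this change, so the guide is thin. Compound 3 otherwise matches compound 2 (43 nM), but compound 1 (710000 nM) also carries an aromatic ring at that place. An expected step of a 23-fold higher number from compound 2 to compound 3 (1.37 log units; beyond the scatter) therefore points toward weaker inhibition in this assay. Compound 3 is estimated at 1000 nM, with an expected range of 60 nM to 20000 nM.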

Compound 3, half-maximal inhibitory concentration: 860 nM
For compound 3 the middle estimate is 1.2-fold (0.07 log units) above the measured one; low and high end bracket the measured number.
By their numbers in this assay, from the lowest: compound 2; then compound 3; then compound 1.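

Within the data shown here, on the five-membered aromatic ring, this is the first direct measure of a change at this place: in this assay, putting 4-hydroxyphenyl in place of pyrrolidin-2-yl gives a 20-fold higher number from compound 2 to compound 3 (1.30 log units; beyond the scatter), a clear loss of inhibition. The leaving and entering groups carry matching counts of hydrogen-bond donors and acceptors, so those counts alone do not preserve the activity of compound 2. No measurement on hand explains the step. On these data alone, it remains open whether a plain phenyl would behave like compound 3, or a piperidin-2-yl like compound 2. An open-chain amine at this place is equally untested by these compounds.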